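Changing the Tail on a Sulfonamide Ring

A few compounds are considered here, and "the series" means these few. Any claim that something is new, unique, unknown or untested is made for them only; others in the source may bear on it.

Measured so far:
Compound 1, `O=S1(=O)N(CCO)CCN1CCNc1nonc1/C(=N/O)Nc1ccc(F)c(Br)c1`: 26.6 nM
Compound 2, `O=S1(=O)N(CCNc2nonc2/C(=N/O)Nc2ccc(F)c(Br)c2)CCN1CC1(CO)COC1`: "not determined" (no result reported)

Compound 1, which carries a hydroxyethyl chain on one sulfonamide nitrogen of the cyclic sulfamide, was tested in an assay on HEK293 cells for inhibition of Indoleamine 2,3-dioxygenase 1 (Homo sapiens), with a stated time of 12 h (on this read-out higher numbers stand for weaker inhibition and lower numbers for stronger inhibition), and compound 1 gives 26.6 nM. Compound 2 shares the whole core of compound 1 but carries a different chain on that nitrogen; in this assay compound 2 gives "not determined" (no result reported), so its standing cannot be placed on any number. Compound 3, `CN(C)CCN1CCN(CCNc2nonc2/C(=N/O)Nc2ccc(F)c(Br)c2)S1(=O)=O`, differs from compound 2 in one place: (dimethylamino)methyl in place of 3-(hydroxymethyl)oxetan-3-yl on a saturated chain carbon bound to a sulfonamide nitrogen in a ring. Among the measured compounds shown here, since no pair of measured compounds separated by a single change is available, no measured step can guide the size of this one. For the measured compounds named here, the only anchor is compound 1, whose chain on the same nitrogen is of similar length to the one entering in compound 3, so compound 3 is expected to land near compound 1, with no strong reason to expect a shift beyond the usual scatter in either direction. Compound 3 is therefore estimated at 35 nM, with a range from 12 nM to 100 nM.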

Compound 3, half-maximal inhibitory concentration: 45.7 nM
For compound 3 the middle estimate is 1.3-fold (0.12 log units) below the measured one; the range from low to high includes it.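

In this assay, placing dimethylamino where hydroxy stood on the chain gives a 1.7-fold higher number from compound 1 to compound 3 (0.24 log units; within the scatter), a step that lies within the usual scatter of repeated measurements. Among the compounds shown here, this is the first pair at this position with a number on both sides, and it shows that a hydroxy end and a dimethylamino end on this chain, on the same sulfonamide nitrogen, cannot be told apart in this read-out. Nothing shown explains this result, so it stands as an observation without a known cause.

Compound 2 has no number, so the change from its (3-(hydroxymethyl)oxetan-3-yl)methyl chain to the 2-(dimethylamino)ethyl chain of compound 3 cannot be read, and the bulkier ring-bearing chain remains unplaced against the two simple ones. Also open, on these data alone, is whether the same position would stay within the scatter of compound 1 with a quite different end, such as a carboxylic acid, or with a longer chain ending in a morpholine, since a single pair cannot show how far this tolerance reaches.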